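The source may report more compounds than this note shows. Statements on the series, on what has been measured and on what is new or still open speak of the compounds shown alone.

In a functional assay with Homo sapiens as the target (a lower number here means a stronger inhibitor, a higher number a weaker inhibitor), three compounds with a shared core have been measured: compound 1 `CC(C)[C@H](NC(=O)COc1cccc2ccccc12)C(=O)N[C@@H](CC(=O)O)C(=O)COC(=O)c1c(Cl)cccc1Cl` gives 11500 nM, compound 2 `CC(C)[C@H](NC(=O)COc1cccc2ccccc12)C(=O)N[C@@H](CC(=O)O)C(=O)COc1ccc(F)c(F)c1` gives 16200 nM, and compound 3 `CC(C)[C@H](NC(=O)COc1cccc2ccccc12)C(=O)N[C@@H](CC(=O)O)C(=O)COc1cc(F)cc(F)c1` gives 15900 nM. Compound 3 thus stands level with the other two, all within the usual scatter of repeat measurements. In compound 4 `CC(C)[C@H](NC(=O)COc1cccc2ccccc12)C(=O)N[C@@H](CC(=O)O)C(=O)COc1c(F)c(F)c(F)c(F)c1F`, the change lies on an oxygen on a saturated carbon: 2,3,4,5,6-pentafluorophenyl in place of 3,5-difluorophenyl on an oxygen on a saturated carbon.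

Within the data shown here, three measured steps bear on this change: a 1.0-fold lower number from compound 2 to compound 3 (0.01 log units; within the scatter), a 1.4-fold higher number from compound 1 to compound 2 (0.15 log units; within the scatter) and a 1.4-fold higher number from compound 1 to compound 3 (0.14 log units; within the scatter). All are within the scatter, though none of them tests the pentafluorophenyl group itself. No step beyond the scatter is therefore expected, in either direction. The estimate is an expected 1.2-fold lower number from compound 3 to compound 4 (0.09 log units; within the scatter). For compound 4, the expected value is 13000 nM, with an estimated range of 5000 nM to 26000 nM.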

Compound 4, half-maximal inhibitory concentration: 8890 nM
Estimate against measurement, compound 4: 1.5-fold (0.17 log units) above; measured number inside the range.
By their numbers in this assay, from the lowest: compounds 4, 1, 3 and 2 (each within the scatter of the next).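

In this assay, 2,3,4,5,6-pentafluorophenyl gives a 1.8-fold lower number from compound 3 to compound 4 (0.25 log units; within the scatter), a 1.8-fold lower number from compound 2 to compound 4 (0.26 log units; within the scatter) and a 1.3-fold lower number from compound 1 to compound 4 (0.11 log units; within the scatter). Going from 3,5-difluorophenyl to 2,3,4,5,6-pentafluorophenyl, with its larger count of fluorine and heavy atoms, therefore moves the number no further than the scatter, so this position has so far tolerated every aromatic group shown. Nothing available explains why these numbers lie so close together.

All four compounds carry an aromatic ring here. Going by these compounds, how an amine, a carboxylic acid or a plain saturated chain would read at this place stays open.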